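The compounds below may be only part of what the source reports. "The series", "measured", "known", "first", "only" and "open" are said of these compounds alone.

Compound 2, `Cc1cc(SC(C)(C)C)c(S(C)(=O)=O)cc1C(=O)N=C(N)N`, gives 22 nM in a functional assay for inhibition of sodium/hydrogen exchanger (Oryctolagus cuniculus); a lower number here means a stronger inhibitor, a higher number a weaker inhibitor. That is the lower of the two numbers shown, but compound 1, `Cc1cc(-c2ccc(Cl)cc2Cl)c(S(C)(=O)=O)cc1C(=O)N=C(N)N`, gives 42 nM, and the step of a 1.9-fold lower number from compound 1 to compound 2 (0.28 log units; within the scatter) lies within the scatter, so the two compounds cannot be told apart on these measurements.

Compound 3, `Cc1cc(Oc2ccccc2)c(S(C)(=O)=O)cc1C(=O)N=C(N)N`, has not been measured. The change from compound 2 to compound 3 is phenoxy in place of (tert-butyl)sulfanyl on an aromatic carbon.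

For the measured compounds named here, only one measured step bears on this change: the step from compound 1 to compound 2 swapped a 2,4-dichlorophenyl group for a (tert-butyl)sulfanyl group at the same place, and it moved the number by a 1.9-fold lower number from compound 1 to compound 2 (0.28 log units; within the scatter), within the scatter. Compound 3 returns a ring to that place, now as phenoxy, so the expectation is a number close to those of compound 1 and compound 2, with the step of a 1.6-fold higher number from compound 2 to compound 3 (0.20 log units; within the scatter) expected to stay inside the scatter. Compound 3 is therefore estimated at 35 nM, in a range from 12 nM to 110 nM.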

Compound 3, half-maximal inhibitory concentration: 10 nM
Compound 3: middle estimate off by 3.5-fold (0.54 log units), on the high side, outside the stated range (below it).
By their numbers in this assay, from the lowest: compound 3; then compounds 2 and 1 (each within the scatter of the next).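

In this assay, for the compounds shown here, the place ortho to the methylsulfonyl group now clearly responds to what sits on it, which the single earlier step, within the scatter, could not show: phenoxy in place of (tert-butyl)sulfanyl gives (a 2.2-fold lower number from compound 2 to compound 3 (0.34 log units; beyond the scatter)), and phenoxy in place of 2,4-dichlorophenyl gives (a 4.2-fold lower number from compound 1 to compound 3 (0.62 log units; beyond the scatter)), both modest in size. Compound 3 therefore has the lowest number of the three, and having a six-membered aromatic ring at this place does not by itself sort the compounds, since compound 1 also carries one there yet cannot be told apart from compound 2, which has no ring. No measurement here explains why phenoxy gives the lower number.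

Phenoxy also differs from 2,4-dichlorophenyl in two ways at once, the oxygen link and the two chlorines, so these compounds cannot say which of the two matters. From the compounds shown here alone, an unsubstituted phenyl group, a 2,4-dichlorophenoxy group or a phenylsulfanyl group at the same place would separate these features, and the effect of an amine link, as in anilino, also remains open.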